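A Shorter Chain Between the Ring and the Selenium Group

The source may hold more compounds than are shown below. What is called first, only, known or untested is meant among the compounds shown, and "the series" means these compounds.

Compound 1 `COc1ccc(N(C)c2nc(C)nc3ccccc23)cc1`: 8 nM
Compound 2 `COc1ccc(N(C)c2nc(C)nc3ccccc23)cc1OCCCCCC[Se]C#N`: 8580 nM
Compound 3 `COc1ccc(N(C)c2nc(C)nc3ccccc23)cc1[Se]C#N`: 73 nM

All three were tested in a functional assay on LoVo cells (Homo sapiens) for inhibition, read by MTT assay, with a stated time of 48 h; a higher number here means a weaker inhibitor, a lower number a stronger inhibitor. Compound 3 stands second highest of the three numbers: the step of a 9.1-fold higher number from compound 1 to compound 3 (0.96 log units; beyond the scatter) is modest, while the step of a 120-fold lower number from compound 2 to compound 3 (2.07 log units; beyond the scatter) is large. Compound 4 `COc1ccc(N(C)c2nc(C)nc3ccccc23)cc1OCCC[Se]C#N` has not been measured. It differs from compound 3 in one place: a group of 7 heavy atoms (4 carbon, 1 nitrogen, 1 oxygen, 1 selenium; no ring) in place of a group of 3 heavy atoms (1 carbon, 1 nitrogen, 1 selenium; no ring), on an aromatic carbon. Among the compounds with values here, the entering chain is shorter than the one carried by compound 2, so compound 4 may be expected to fall between its two measured relatives. The step of a 1100-fold higher number from compound 1 to compound 2 (3.03 log units; beyond the scatter) shows how much the long chain cost, and a 120-fold lower number from compound 2 to compound 3 (2.07 log units; beyond the scatter) how much its removal gave back. A rise beyond the scatter is therefore expected, a 14-fold higher number from compound 3 to compound 4 (1.14 log units; beyond the scatter), yet smaller than a full reversal of that step. Compound 4 is estimated at 1000 nM, likely between 200 nM and 5000 nM.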

Compound 4, half-maximal inhibitory concentration: 921 nM
Beside the measured number, compound 4's estimate is 1.1-fold (0.04 log units) above it; the range from low to high includes it.
By their numbers in this assay, from the lowest: compound 1; then compound 3; then compound 4; then compound 2.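

With the oxygen-linked chain shortened, a 9.3-fold lower number from compound 2 to compound 4 (0.97 log units; beyond the scatter), so a shorter chain at this position gives back part of what the longer chain lost. Even so, the shorter chain stays far from the core with no chain, a 120-fold higher number from compound 1 to compound 4 (2.06 log units; beyond the scatter), and it also compares poorly with the selenium group set directly on the ring, a 13-fold higher number from compound 3 to compound 4 (1.10 log units; beyond the scatter). Nothing given here explains these steps. Still open, on these data alone, is how a chain of intermediate length would behave, or an amine in place of the selenium-bearing end.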